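This account rests on a few compounds, and the source may have more. Where it says the series, first, only, none or still open, it means among the compounds named here.

Working notes on the series, read in a functional assay on HeLa cells (Homo sapiens) for antiproliferative activity, read by MTT assay, with a stated time of 48 h; on this read-out lower numbers stand for stronger inhibition and higher numbers for weaker inhibition. Compound 1, `Cn1cc(-c2cnc3ccc(N)nc3c2)cn1`, gives > 50000 nM, which is a limit of the assay and not a number. Compound 2, `Cn1cc(-c2cnc3ccc(NCc4ccc(F)cc4)nc3c2)cn1`, gives 46600 nM. Compound 3, `Cn1cc(-c2cnc3ccc(NS(=O)(=O)c4ccc(C(F)(F)F)cc4)nc3c2)cn1`, gives > 50000 nM, again only a limit. The series therefore stands at the limit of > 50000 nM in this assay, at which 2 of the 3 values shown sit, and compound 3 has no number of its own to start from.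

The next change leads to compound 4, `Cn1cc(-c2cnc3ccc(NS(=O)(=O)c4ccc(Cl)cc4Cl)nc3c2)cn1`: 2,4-dichlorophenyl in place of 4-(trifluoromethyl)phenyl on a sulfonyl sulfur. In words, 2,4-dichlorophenyl in place of 4-(trifluoromethyl)phenyl on a sulfonyl sulfur.

Within the data shown here, only one measured step exists, an at least 1.0-fold lower number from compound 1 to compound 2 (0.03 log units; that floor lies within the scatter). It lies at a different place in the structure and gives no direct reading on a change at the sulfonyl sulfur. Among the measured compounds shown here, no measured pair shows an exchange of this kind. For the measured compounds named here, the one measured step stays within the scatter, so it offers no ground for expecting a large move, and no direction is firmly supported. The expected change is an at least 1.3-fold lower number from compound 3 to compound 4 (0.11 log units; that floor lies within the scatter), an estimate of no step beyond the scatter.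

For compound 4 the expected value is 38000 nM, with an estimated range of 10000 nM to 50000 nM. A result reported only as a limit would also be expected.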

Compound 4, half-maximal inhibitory concentration: > 50000 nM
Compound 4 was reported as a limit (the forecaster's own chance of this, stated with the estimate: 55%); middle value at least 1.3-fold (0.11 log units) from the limit.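

In this assay compound 3 gives > 50000 nM, a limit and not a number. Compound 4 gives > 50000 nM, again a limit, so no step can be read between compound 3 and compound 4. The series now stands as follows: the limit of > 50000 nM in this assay, at which 3 of the 4 values shown sit. Still open, from the compounds shown here alone, is how 2,4-dichlorophenyl and 4-(trifluoromethyl)phenyl on a sulfonyl sulfur compare in this read-out.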